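Amine Chain Replaces Hydroxymethylphenyl on the Ketone

This account rests on a few compounds, and the source may have more. Where it says the series, first, only, none or still open, it means among the compounds named here.

Compound 1 `Cc1ccc(C(=O)c2ccn(-c3ccc4c(c3)B(O)OC4)c2)cc1` and compound 2 `Cc1cccc(C(=O)c2ccn(-c3ccc4c(c3)B(O)OC4)c2)c1` share their core with compound 3 `O=C(c1ccc(CO)cc1)c1ccn(-c2ccc3c(c2)B(O)OC3)c1` and differ from it only in the group on the carbonyl carbon. In an ADME assay on L929 cells (Mus musculus) for cytotoxicity, read by resazurin assay, with a stated time of 72 h (a higher number here means a weaker inhibitor, a lower number a stronger inhibitor), compound 1 gives > 10 ug/mL, a limit of the assay rather than a number. Compound 2 gives > 10 ug/mL, also a limit. For the measured compounds named here, compound 3 gives 9.31 ug/mL, the only true number of the three. Compounds 1 and 2 both sit at the limit of > 10 ug/mL in this assay, at which 2 of the 3 values shown sit. Between them lies a step that the two limits leave unreadable from compound 1 to compound 2, and the changes at the carbonyl carbon show only floors: an at least 1.0-fold lower number from compound 1 to compound 3 (0.03 log units; that floor lies within the scatter) and an at least 1.0-fold lower number from compound 2 to compound 3 (0.03 log units; that floor lies within the scatter). Compound 4 `NCCCC(=O)c1ccn(-c2ccc3c(c2)B(O)OC3)c1` carries 3-aminopropyl in place of 4-(hydroxymethyl)phenyl on a carbonyl carbon. Since the measured steps at this position are all floors or unreadable, no change beyond the scatter is expected in this assay. Compound 4 is estimated at 10 ug/mL, within 5 ug/mL to 20 ug/mL. That expectation amounts to a 1.1-fold higher number from compound 3 to compound 4 (0.03 log units; within the scatter).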

Compound 4, half-maximal inhibitory concentration: > 10 ug/mL
Compound 4 ended at the assay's limit; the forecaster's own chance of this, stated with the estimate: 60%; the middle value lies on the limit itself.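

Putting 3-aminopropyl in place of 4-(hydroxymethyl)phenyl on the carbonyl carbon gives, in this assay, an at least 1.0-fold higher number from compound 3 to compound 4 (0.03 log units; that floor lies within the scatter), a floor that leaves the true size of the step unknown. The steps from compound 1 and compound 2 to compound 4 cannot be read, since both ends are limits. New here is that a group with no ring reaches the same limit as the ring-bearing groups of compound 1 and compound 2: the limit of > 10 ug/mL in this assay, at which 3 of the 4 values shown sit.

As far as these compounds go, how far past that limit these compounds lie stays open. So does whether a carboxylic acid or a longer amine chain at this carbonyl carbon would give a readable number.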